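A few compounds are considered here, and "the series" means these few. Any claim that something is new, unique, unknown or untested is made for them only; others in the source may bear on it.

Measured so far in a functional assay on HeLa cells (Homo sapiens) for antiproliferative activity, read by cell counting, with a stated time of 3 days; a higher number here means a weaker inhibitor, a lower number a stronger inhibitor:

Compound 1 `COc1ccc(Oc2ccccc2NC(C)=C2C(=O)CC(c3ccccc3)CC2=O)cc1` gives 160 nM.
Compound 2 `CC(Nc1ccccc1Oc1cccc(N)c1)=C1C(=O)CC(c2ccccc2)CC1=O` gives 82 nM.
Compound 3 `CC(Nc1ccccc1Oc1ccc(C(C)O)cc1)=C1C(=O)CC(c2ccccc2)CC1=O` gives 75 nM.

Compound 3 has the lowest of the three numbers, but its standing is only partly secure: the step of a 1.1-fold lower number from compound 2 to compound 3 (0.04 log units; within the scatter) lies within the scatter, so compound 2 and compound 3 cannot be told apart, whereas the step of a 2.1-fold lower number from compound 1 to compound 3 (0.33 log units; beyond the scatter) is beyond the scatter and modest in size.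

Compound 4 `CC(Nc1ccccc1Oc1ccc(N)cc1)=C1C(=O)CC(c2ccccc2)CC1=O` differs from compound 3 in one place: amino in place of 1-hydroxyethyl on an aromatic carbon.

Among the compounds with values here, two measured steps bear on this. The step of a 1.1-fold lower number from compound 2 to compound 3 (0.04 log units; within the scatter) swaps a 3-aminophenyl for a 4-(1-hydroxyethyl)phenyl on the ring oxygen and changes nothing beyond the scatter; the step of a 2.0-fold lower number from compound 1 to compound 2 (0.29 log units; within the scatter) brings an amino group in for a methoxy-bearing ring and also stays within the scatter. Neither suggests that putting an amino group on this outer ring moves the number far. The change to compound 4 keeps the same amino group, now as 4-aminophenyl, in place of the 1-hydroxyethyl. A step of about a 1.1-fold higher number from compound 3 to compound 4 (0.03 log units; within the scatter) is therefore expected, that is, none beyond the scatter.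

Compound 4 is estimated at 80 nM, with a range from 40 nM to 160 nM.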

Compound 4, half-maximal inhibitory concentration: 39 nM
For compound 4 the middle estimate is 2.1-fold (0.31 log units) above the measured one; measured number outside the range, below it.
By their numbers in this assay, from the lowest: compounds 4, 3, 2 and 1 (each within the scatter of the next, the first and the last beyond it).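

In this assay, the step from the 3-aminophenyl to the 4-aminophenyl group (a 2.1-fold lower number from compound 2 to compound 4 (0.32 log units; beyond the scatter)) gives the first sign that the place of the amino group on this ring matters, although the effect is modest. At the carbon para to a large group, amino and 1-hydroxyethyl cannot be told apart (a 1.9-fold lower number from compound 3 to compound 4 (0.28 log units; within the scatter)), even though amino has only one heavy atom and 1-hydroxyethyl has three, whereas amino in place of methoxy gives the widest gap among these four compounds (a 4.1-fold lower number from compound 1 to compound 4 (0.61 log units; beyond the scatter)), still a modest one. No independent measurement accompanies these numbers to account for the differences.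

The compounds shown leave open whether the free amino group itself is needed at this carbon, which a methylamino, dimethylamino or acetamido group there could test. They also leave open how a hydroxyl or a carboxylic acid at the same carbon would compare with amino and 1-hydroxyethyl, and so whether groups of other kinds fit there as well.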